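Ethyl in place of hydroxymethyl on the triazole of compound 3

The source may report more compounds than this note shows. Statements on the series, on what has been measured and on what is new or still open speak of the compounds shown alone.

Compound 3 `O=C1O[C@@H](Cn2cc(CO)nn2)CN1c1ccc(C2=CCS(=O)(=O)CC2)c(F)c1` gives 47000 nM in an assay for binding affinity to Amine oxidase [flavin-containing] A (Homo sapiens) (on this read-out lower numbers stand for stronger inhibition and higher numbers for weaker inhibition), the highest of the two numbers shown; its nearest neighbour is compound 1 `O=C1O[C@@H](Cn2cc(Cl)nn2)CN1c1ccc(C2=CCS(=O)(=O)CC2)c(F)c1`, which gives 3000 nM. Compound 2 `C[Si](C)(C)C#Cc1cn(C[C@H]2CN(c3ccc(C4=CCS(=O)(=O)CC4)c(F)c3)C(=O)O2)nn1` gives only a limit in this assay, > 200000 nM, and it sits at the limit of > 200000 nM in this assay, at which 1 of the 3 values shown sits. Compound 4 `CCc1cn(C[C@H]2CN(c3ccc(C4=CCS(=O)(=O)CC4)c(F)c3)C(=O)O2)nn1` differs from compound 3 by methyl in place of hydroxy on a saturated chain carbon bound to an aromatic carbon. Among the compounds with values here, two measured steps bear on it. The step of a 16-fold higher number from compound 1 to compound 3 (1.19 log units; beyond the scatter) shows that going from chloro to hydroxymethyl weakened binding strongly, while an at least 4.2-fold lower number from compound 2 to compound 3 (0.62 log units; beyond the scatter) shows that hydroxymethyl was nonetheless better than the larger silicon-bearing group. Ethyl, like chloro, carries no hydrogen-bond donor or acceptor and is small, so compound 4 is expected to move back toward compound 1, a step of a 4.7-fold lower number from compound 3 to compound 4 (0.67 log units; beyond the scatter) that is expected to lie beyond the scatter. Compound 4 is therefore estimated at 10000 nM in this assay, within a range from 3000 nM to 40000 nM.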

Compound 4, inhibition constant: > 200000 nM
Compound 4 ended at the assay's limit; the forecaster's own chance of this, stated with the estimate: 5%; middle value at least 20-fold (1.30 log units) from the limit.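

In this assay compound 4 gives > 200000 nM, which is a limit of the assay and not a number. Methyl in place of hydroxy, a change of one heavy atom that removes a hydrogen-bond donor and acceptor, gives an at least 4.2-fold higher number from compound 3 to compound 4 (0.62 log units; beyond the scatter), and ethyl in place of chloro gives an at least 66-fold higher number from compound 1 to compound 4 (1.82 log units; beyond the scatter), so at this position ethyl ranks behind both hydroxymethyl and chloro. The step from compound 2 to compound 4 cannot be read, as ethyl and the silicon-bearing group now share one end of the scale: the limit of > 200000 nM in this assay, at which 2 of the 4 values shown sit.

From the compounds shown here alone, it remains open whether any group at this position would give a lower number than chloro does in compound 1. A methoxy group, an amine or a carboxylic acid could show whether the oxygen of hydroxymethyl matters there.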